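Propyl for Cyclopropyl on the Amino Group: Cytotoxicity Outlook

A few compounds are considered here, and "the series" means these few. Any claim that something is new, unique, unknown or untested is made for them only; others in the source may bear on it.

Measured compounds:
Compound 1 `Nc1nc(OCC(F)(F)F)c2ncn(/C=C3/CC3(CO)CO)c2n1` gives > 300000 nM in an ADME assay on HFF cells (Homo sapiens) for cytotoxicity, with a stated time of 8 days; on this read-out higher numbers stand for lower toxicity in this test and lower numbers for higher toxicity in this test.
Compound 2 `Nc1nc(NC2CC2)c2ncn(/C=C3/CC3(CO)CO)c2n1` gives > 300000 nM in this assay.

The value of compound 1 in this assay is a limit of the test, not a number. The value of compound 2 in this assay is likewise a limit. The step that the two limits leave unreadable from compound 1 to compound 2 therefore cannot be read, since the limit of > 300000 nM in this assay, at which 2 of the 2 values shown sit, places both values at the same limit. Compound 3 is `CCCNc1nc(N)nc2c1ncn2/C=C1/CC1(CO)CO`; it differs from compound 2 by propyl in place of cyclopropyl on a nitrogen on an aromatic ring. Within the data shown here, no measured step bears on propyl in place of cyclopropyl on a nitrogen on an aromatic ring, and the one step that was measured is unreadable, so in this assay no step beyond the scatter is expected in either direction. For compound 3 the estimate is 300000 nM, with a range from 100000 nM to 1000000 nM, and the result is expected most likely to be reported again as a limit. The expected step is a number no higher from compound 2 to compound 3 (the limit leaves the size open).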

Compound 3, half-maximal cytotoxic concentration: > 300000 nM
Compound 3 gave a limit, no number; the forecaster's own chance of this, stated with the estimate: 85%; the middle value sits exactly at the limit.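

In this assay compound 3 gives > 300000 nM, which is a limit and not a number. Among these compounds, no step among compound 1, compound 2 and compound 3 can be read, because all three values sit at the same limit: the limit of > 300000 nM in this assay, at which 3 of the 3 values shown sit. The compounds shown leave open whether any of them differs from the others in cytotoxicity.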